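Dropping the Methyl: An Expectation for Compound 4

This account rests on a few compounds, and the source may have more. Where it says the series, first, only, none or still open, it means among the compounds named here.

For the measured compounds named here, compound 3 `C=CC(=O)Nc1cc(S(C)(=O)=O)cc(C)c1Nc1ncc2cc(-c3c(Cl)c(OC)cc(OC)c3Cl)ccc2n1` is one of three compounds measured in a functional assay on Huh-7 cells (Homo sapiens) for inhibition, read by sulforhodamine B assay, with a stated time of 72 h (on this read-out higher numbers stand for weaker inhibition and lower numbers for stronger inhibition), where compound 3 gives 1940 nM. That number is the second highest of the three. Compound 2 `C=CC(=O)Nc1cc(SC)ccc1Nc1ncc2cc(-c3c(Cl)c(OC)cc(OC)c3Cl)ccc2n1` gives 936 nM in this assay, and compound 1 `C=CC(=O)Nc1cc(CCCN2CCCC2)cc(C)c1Nc1ncc2cc(-c3c(Cl)c(OC)cc(OC)c3Cl)ccc2n1` gives 4260 nM in this assay. Going by the values given here, the only single-point step among the measured compounds runs a 2.2-fold lower number from compound 1 to compound 3 (0.34 log units; beyond the scatter), a modest step that lies beyond the scatter.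

Compound 4 `C=CC(=O)Nc1cc(S(C)(=O)=O)ccc1Nc1ncc2cc(-c3c(Cl)c(OC)cc(OC)c3Cl)ccc2n1` differs from compound 3 by hydrogen in place of methyl on an aromatic carbon. Among the compounds with values here, none of the measured steps touches this change: the step from compound 1 to compound 3 alters the methylsulfonyl side of the ring, not the methyl, and compound 2 differs from both compound 3 and compound 4 in more than one place, so its value can only be noted beside theirs, not used as a step. Within the data shown here, with no measured step bearing on the removal of the methyl, the change expected in this assay is small, most likely within the scatter, with at most a slight lean toward a lower number. For compound 4 the estimated step is a 1.3-fold lower number from compound 3 to compound 4 (0.11 log units; within the scatter). Compound 4 is therefore expected to give about 1500 nM in this assay, with a range from 600 nM to 3500 nM.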

Compound 4, half-maximal inhibitory concentration: 2160 nM
Compound 4: the middle estimate sits 1.4-fold (0.16 log units) below what was measured, and the stated range covers the measured number.
By their numbers in this assay, from the lowest: compound 2; then compounds 3, 4 and 1 (each within the scatter of the next, the first and the last beyond it).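

In this assay, for the compounds shown here, the methyl on the aromatic carbon ortho to a large group turns out not to matter with a methylsulfonyl group on the same ring: a 1.1-fold higher number from compound 3 to compound 4 (0.05 log units; within the scatter) is the whole effect of hydrogen in place of methyl, and the earlier compounds offered no reading of this change at all. Going by these compounds alone, compound 4 also supplies the first comparison in which only the sulfur group differs, and a 2.3-fold higher number from compound 2 to compound 4 (0.36 log units; beyond the scatter) goes with methylsulfonyl in place of methylsulfanyl, so of these two single changes only the one at the sulfur group lies beyond the scatter. No measurement available here offers a reason for either step.

The methyl result rests on a single pair carrying methylsulfonyl, so the compounds shown leave open whether the same change would also read as flat with methylsulfanyl or 3-(pyrrolidin-1-yl)propyl on the ring. Also open, from the compounds shown here alone, is what an ethyl group on that aromatic carbon, or a carboxylic acid in the place of the methylsulfonyl group, would do to the number in this assay.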